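The source may report more compounds than this note shows. Statements on the series, on what has been measured and on what is new or still open speak of the compounds shown alone.

Two compounds of this series carry numbers in an assay on a protein complex for inhibition of ubiquitin carboxyl-terminal hydrolase 1/WD repeat-containing protein 48 (Homo sapiens), read by fluorescence; a higher number here means a weaker inhibitor, a lower number a stronger inhibitor. Compound 1, `Cc1ccc(CNc2nc(-c3ccccc3C(F)(F)F)nc3ccccc23)s1`, gives 5100 nM in this assay, and compound 2, `FC(F)(F)c1ccc(CNc2nc(-c3ccccc3C(F)(F)F)nc3ccccc23)cc1`, gives 8900 nM. Among the compounds with values here, compound 2 holds the highest of the two numbers; its nearest neighbour is compound 1, and the only step recorded, a 1.7-fold higher number from compound 1 to compound 2 (0.24 log units; within the scatter), lies within the scatter, so the two cannot be ordered.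

Compound 3, `FC(F)(F)c1cc(-c2ccc(CNc3nc(-c4ccccc4C(F)(F)F)nc4ccccc34)cc2)ccn1`, differs from compound 2 in one place: 2-(trifluoromethyl)pyridin-4-yl in place of trifluoromethyl on an aromatic carbon, on an aromatic carbon of a six-membered aromatic ring of carbon only, para to a large group. Within the data shown here, no measured step touches this position; the one step known concerns the other end of the chain and was small. The change from compound 2 to compound 3 therefore carries no clear expectation of direction, and a step within the scatter, a 1.3-fold lower number from compound 2 to compound 3 (0.10 log units; within the scatter), is expected. Compound 3 is estimated at 7000 nM in this assay, with a range from 1800 nM to 28000 nM.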

Compound 3, half-maximal inhibitory concentration: 4900 nM
Compound 3: the middle estimate sits 1.4-fold (0.15 log units) above what was measured, within the range that was stated.
By their numbers in this assay, from the lowest: compounds 3, 1 and 2 (each within the scatter of the next).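

In this assay, the aromatic carbon para to a large group takes 2-(trifluoromethyl)pyridin-4-yl in place of trifluoromethyl with no step beyond the scatter (a 1.8-fold lower number from compound 2 to compound 3 (0.26 log units; within the scatter)). This is the first information on this position: a substituent with a second six-membered aromatic ring and a hydrogen-bond acceptor leaves compound 3 and compound 2 unordered, so the space occupied by trifluoromethyl is not shown to be a limit on substitution here. No available evidence bears on why this exchange produces so small a step. Going by these compounds, it remains open whether the ring nitrogen or the trifluoromethyl of the entering group contributes anything. On these data alone, it also remains open whether a carboxylic acid, a primary amine or a longer alkyl chain on this carbon would give a step beyond the scatter.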